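A few compounds are considered here, and "the series" means these few. Any claim that something is new, unique, unknown or untested is made for them only; others in the source may bear on it.

Working notes on the series.

Two compounds carry numbers in a functional assay on HeLa cells (Homo sapiens) for antiproliferative activity, read by MTT assay, with a stated time of 72 h; on this read-out higher numbers stand for weaker inhibition and lower numbers for stronger inhibition. Compound 1 `Cc1ccc(-c2cn(C/C=C3\OC(=O)C(OCc4ccccc4)=C3OCc3ccccc3)nn2)cc1` gives 7480 nM in this assay. Compound 2 `O=C1O[C@H]([C@@H](O)Cn2cc(-c3cccc(O)c3)nn2)C(OCc2ccccc2)=C1OCc1ccccc1` gives 39300 nM in this assay, the highest of the two numbers; its nearest neighbour is compound 1, whose number stands lower by a margin beyond the usual scatter. Among the compounds with values here, no single-point step between the two measured compounds can be described, as they differ in more than one place.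

Compound 3 `COc1ccccc1-c1cn(C[C@H](O)[C@H]2OC(=O)C(OCc3ccccc3)=C2OCc2ccccc2)nn1` has not been measured in this assay. It differs from compound 2 by 2-methoxyphenyl in place of 3-hydroxyphenyl on an aromatic carbon. Within the data shown here, no measured pair shows this change, so nothing in the numbers speaks directly to its size. The expectation is a modest move toward a lower number, as the step of a 1.6-fold lower number from compound 2 to compound 3 (0.20 log units; within the scatter) expresses, though the case for no step beyond the scatter is nearly as strong. Compound 3 is therefore estimated at 25000 nM in this assay, within a range from 8000 nM to 70000 nM.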

Compound 3, half-maximal inhibitory concentration: > 100000 nM
Compound 3 gave a limit, no number; the forecaster's own chance of this, stated with the estimate: 10%; middle value at least 4.0-fold (0.60 log units) away from the limit.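

In this assay, within the data shown here, 2-methoxyphenyl in place of 3-hydroxyphenyl on an aromatic carbon of the five-membered ring is the only single-place change, and it gives an at least 2.5-fold higher number from compound 2 to compound 3 (0.40 log units; beyond the scatter). This shows that the read-out at this position depends on the aryl group carried there, and that this change moves it toward weaker inhibition rather than leaving it unchanged. The result for compound 3 is a limit of the assay, not a number, so the step gives only a minimum size: the limit of > 100000 nM in this assay, at which 1 of the 3 values shown sits.

The change alters both the substituent and its place on the phenyl ring, and the compounds shown do not separate these two parts. Also open, from the compounds shown here alone, is how unsubstituted phenyl, or a phenyl ring carrying an amine or a carboxylic acid, would read at this position.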